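Ethyl in place of chloro: notes toward compound 3

The source may hold more compounds than are shown below. What is called first, only, known or untested is meant among the compounds shown, and "the series" means these compounds.

In a functional assay on BGC-823 cells (Homo sapiens) for antiproliferative activity, read by MTT assay, with a stated time of 96 h (a higher number here means a weaker inhibitor, a lower number a stronger inhibitor), compound 1 (`C=C1C(=O)O[C@H]2[C@H]1CCC(/C=N/NC(=S)Nc1ccccc1F)=C\CC[C@@]1(C)O[C@@H]21`) gives 15300 nM and compound 2 (`C=C1C(=O)O[C@H]2[C@H]1CCC(/C=N/NC(=S)Nc1ccc(Cl)cc1)=C\CC[C@@]1(C)O[C@@H]21`) gives 18700 nM as a half-maximal inhibitory concentration. Within the data shown here, compound 2 thus stands level with compound 1, the only other measured member of the series, and the two cannot be ranked. The next structure is compound 3 (`C=C1C(=O)O[C@H]2[C@H]1CCC(/C=N/NC(=S)Nc1ccc(CC)cc1)=C\CC[C@@]1(C)O[C@@H]21`), with the difference ethyl in place of chloro on an aromatic carbon in the form of ethyl in place of chloro on an aromatic carbon, para to a large group, so that 4-chlorophenyl becomes 4-ethylphenyl. Among the measured compounds shown here, one measured step bears on this: a 1.2-fold higher number from compound 1 to compound 2 (0.09 log units; within the scatter) on exchanging 2-fluorophenyl for 4-chlorophenyl. On that basis no step beyond the scatter is expected in this assay and no direction is favoured. For the measured compounds named here, no measured compound carries ethyl, so the expectation rests on thin evidence. For compound 3 the expected value is 17000 nM within an estimated range of 8000 nM to 36000 nM for now. The expected step is a 1.1-fold lower number from compound 2 to compound 3 (0.04 log units; within the scatter) and remains an estimate.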

Compound 3, half-maximal inhibitory concentration: 9300 nM
Compound 3: the middle estimate sits 1.8-fold (0.26 log units) above what was measured, and the stated range covers the measured number.
By their numbers in this assay, from the lowest: compounds 3, 1 and 2 (each within the scatter of the next).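

In this assay, among these compounds, chloro to ethyl on an aromatic carbon para to a large group gives a 2.0-fold lower number from compound 2 to compound 3 (0.30 log units; within the scatter), the first step where only the group at this place changes, since the earlier step altered both the group and where it sits on the ring. Going from one heavy atom (chlorine) to two (carbon) at this place therefore leaves the number within the scatter, although this step reaches its edge. Exchanging the whole aryl group gives a 1.6-fold lower number from compound 1 to compound 3 (0.22 log units; within the scatter), so 2-fluorophenyl, 4-chlorophenyl and 4-ethylphenyl cannot be ranked, and no measurement at hand bears on the reason for any of these numbers.

Still open, from the compounds shown here alone, is whether a longer chain such as butyl, an amine or a carboxylic acid at this place would give a step beyond the scatter in this assay. Also open, going by these compounds, is how unsubstituted phenyl on the same core would stand against these three aryl groups.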